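From an aminophenyl ketone to a difluorophenyl ketone

The source may report more compounds than this note shows. Statements on the series, on what has been measured and on what is new or still open speak of the compounds shown alone.

Measured compounds:
compound 1, `COc1cc(-c2cc(/C=C/C(=O)c3ccc(N)cc3)[nH]n2)cc(OC)c1OC`; in a functional assay on HCT-15 cells (Homo sapiens) for cytotoxicity, read by sulforhodamine B assay, with a stated time of 48 h, tested at 0.1 uM (on this read-out higher numbers stand for a weaker effect at the one concentration tested and lower numbers for a stronger effect), compound 1 gives 94%
compound 2, `COc1ccc(-c2cc(/C=C/C(=O)c3cc(OC)c(OC)c(OC)c3)[nH]n2)cc1OC`; in this assay compound 2 gives 90%
compound 3, `COc1cc(C(=O)/C=C/c2cc(-c3cc(OC)c(OC)c(OC)c3)n[nH]2)cc(OC)c1OC`; in this assay compound 3 gives 94%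

Compound 1 stands level with compound 3 at the digits shown, and the two share the highest number of the three; compound 2 lies furthest from compound 1, yet still within the scatter. The only measured step that links two of these compounds is a number 4 percentage points higher from compound 2 to compound 3 (within the scatter), a methoxy in place of hydrogen on an aromatic carbon, and it does not rise above the scatter.

Compound 4, `COc1cc(-c2cc(/C=C/C(=O)c3ccc(F)c(F)c3)[nH]n2)cc(OC)c1OC`, differs from compound 1 in a different place: 3,4-difluorophenyl in place of 4-aminophenyl on a carbonyl carbon. Among the measured compounds shown here, no measured step touches the group on the carbonyl carbon, so the expectation for compound 4 rests only on the narrow band in which compounds 1, 2 and 3 sit. On that basis compound 4 is expected to show no step beyond the scatter, a number 2 percentage points lower from compound 1 to compound 4 (within the scatter). The estimate for compound 4 in this assay is 92%, with a range from 80% to 100%.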

Compound 4, a percentage reported as activity, at one concentration (the size of the read-out at that concentration, not a potency): 95%
Beside the measured number, compound 4's estimate is 3 percentage points below it, and the stated range covers the measured number.
By their numbers in this assay, from the lowest: compounds 2, 1, 3 and 4 (each within the scatter of the next).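

In this assay, among the compounds shown here, the change of 4-aminophenyl to 3,4-difluorophenyl on a carbonyl carbon gives a number 1 percentage points higher from compound 1 to compound 4 (within the scatter), the first measured step at this place; the earlier steps touched only the methoxy pattern. Thus, even with the hydrogen-bond donor and acceptor of 4-aminophenyl gone and two fluorines present instead, the read-out at this one concentration does not move beyond the scatter. No independent evidence bears on this result.

As far as these compounds go, a read-out at one concentration is not a potency, so whether compound 1 and compound 4 differ at other concentrations remains open. Also open, from the compounds shown here alone, is what a carboxylic acid or a dimethylamino group would do on the phenyl ring at this place, since only two substituent patterns on that ring can be compared here.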